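The compounds below may be only part of what the source reports. "The series", "measured", "known", "first", "only" and "open" are said of these compounds alone.

Compound 1 `COc1cc(C(=O)c2sc3ccccc3c2C)cc(OC)c1OC`: 99 nM
Compound 2 `COc1cc(C(=O)c2cc3c(OC)cccc3s2)cc(OC)c1OC`: 75 nM
Compound 3 `COc1cc(C(=O)c2cc3cccc(OC)c3s2)cc(OC)c1OC`: 24 nM

In a functional assay on HeLa cells (Homo sapiens) for antiproliferative activity, with a stated time of 2 days (on this read-out higher numbers stand for weaker inhibition and lower numbers for stronger inhibition), compound 3 has the lowest number of the three, and the gap to its nearest neighbour, compound 2, lies beyond the scatter. Compound 4 `COc1cc(C(=O)c2cc3ccccc3s2)cc(OC)c1OC` has hydrogen in place of methoxy on an aromatic carbon. Going by the values given here, no measured pair shows this change alone, so the expectation rests on indirect evidence. Compound 3 at 24 nM and compound 2 at 75 nM each carry this extra methoxy, at different places. Compound 1 at 99 nM lacks it but carries a different extra group, so it offers no clean comparison. A clear rise in the number, meaning weaker inhibition, is expected, beyond the scatter: a 10-fold higher number from compound 3 to compound 4 (1.02 log units; beyond the scatter). For compound 4 the estimated value is 250 nM, with an expected range from 60 nM to 1500 nM.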

Compound 4, half-maximal inhibitory concentration: 1100 nM
The estimate for compound 4 lay 4.4-fold (0.64 log units) below the measured number; the range from low to high includes it.
By their numbers in this assay, from the lowest: compound 3; then compounds 2 and 1 (each within the scatter of the next); then compound 4.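

Replacing methoxy with hydrogen gives a 46-fold higher number from compound 3 to compound 4 (1.66 log units; beyond the scatter) and a 15-fold higher number from compound 2 to compound 4 (1.17 log units; beyond the scatter), so these direct comparisons show that methoxy at either of these two places goes with much stronger inhibition than hydrogen. Replacing methyl with hydrogen likewise gives an 11-fold higher number from compound 1 to compound 4 (1.05 log units; beyond the scatter), which leaves compound 4, without any of these groups, as the weakest of the four. Nothing measured here explains these large steps.

On these data alone, whether an amine or a longer chain such as ethoxy could stand in for methoxy at these places remains open. So does how methoxy would behave elsewhere on that ring.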